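Amine in place of the sulfonate ester on the shared core

A few compounds are considered here, and "the series" means these few. Any claim that something is new, unique, unknown or untested is made for them only; others in the source may bear on it.

compound 1 `CS(=O)(=O)Oc1c(C(=O)NCc2ccc(F)cc2)nc(Br)c2cccnc12` > 20000 nM
compound 2 `COc1cccc(CNC(=O)c2nc(Br)c3cccnc3c2N[C@H]2CC[C@H](N)CC2)c1` 7000 nM
compound 3 `N[C@H]1CC[C@H](Nc2c(C(=O)NCc3ccc(F)cc3)nc(N3CCCCC3)c3cccnc23)CC1` 5000 nM

All three were read in a functional assay on MDA-MB-435 cells (Homo sapiens) for cytotoxicity, read by MTT assay, with a stated time of 72 h; a higher number here means a weaker inhibitor, a lower number a stronger inhibitor. Within the data shown here, compound 1 gives only a limit of the assay, > 20000 nM, not a number; it is the single value sitting at the limit of > 20000 nM in this assay, at which 1 of the 3 values shown sits. Compound 2 gives 7000 nM and compound 3 gives 5000 nM; these two lie within the scatter of one another. Compound 4 `O=C(NCc1ccc(F)cc1)c1nc(Br)c2cccnc2c1N1CCNCC1` is not yet measured and differs from compound 1 in one place: piperazin-1-yl in place of (methylsulfonyl)oxy on an aromatic carbon. Among the measured compounds shown here, no measured step of this kind exists in the set. Compound 2 and compound 3, both lacking the (methylsulfonyl)oxy group, return numbers rather than a limit. Compound 4 is expected to follow them, with the step of an at least 3.3-fold lower number from compound 1 to compound 4 (0.52 log units; beyond the scatter) running toward stronger inhibition. The estimate for compound 4 is 6000 nM, within 2000 nM to 20000 nM.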

Compound 4, half-maximal inhibitory concentration: 8000 nM
The estimate for compound 4 lay 1.3-fold (0.12 log units) below the measured number; measured number inside the range.
By their numbers in this assay, from the lowest: compounds 3, 2 and 4 (each within the scatter of the next). At a limit, above all of these: compound 1.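

In this assay, among these compounds, the swap of (methylsulfonyl)oxy for piperazin-1-yl on this aromatic carbon gives the only single-place step, an at least 2.5-fold lower number from compound 1 to compound 4 (0.39 log units; beyond the scatter) and this step lies beyond the scatter. The position therefore responds to this change with the bromo group and the amide side chain held constant. As far as these compounds go, compound 1 gives only a limit of the assay, so the true size of the step remains unknown: the limit of > 20000 nM in this assay, at which 1 of the 4 values shown sits.

From the compounds shown here alone, whether the change depends on piperazin-1-yl itself or on an amine more generally stays open. Morpholin-4-yl or a dimethylamino group on the same core would separate these readings.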